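Swapping the Methoxyphenyl for a Pyridine Ring

This account rests on a few compounds, and the source may have more. Where it says the series, first, only, none or still open, it means among the compounds named here.

Compound 1 `COC(=O)c1sc2cc(C#Cc3ccc(OC)cc3)cnc2c1N` carries a 4-methoxyphenyl on a triple-bonded carbon attached to the shared core. In a functional assay on NCI-H460 cells (Homo sapiens) for inhibition, read by sulforhodamine B assay, with a stated time of 48 h (on this read-out higher numbers stand for weaker inhibition of growth and lower numbers for stronger inhibition of growth), compound 1 gives 320 nM, the lowest of the two plain numbers available here. Compound 2 `COC(=O)c1sc2cc(C#Cc3cccc(N)c3)cnc2c1N` carries a 3-aminophenyl at that place, and in this assay compound 2 gives 11500 nM; that is a 36-fold higher number from compound 1 to compound 2 (1.56 log units; beyond the scatter). Compound 3 `COC(=O)c1sc2cc(C#Cc3ccccc3F)cnc2c1N` carries a 2-fluorophenyl there. For compound 3 this assay reports only a limit, > 150000 nM, not a number. The steps toward it, an at least 460-fold higher number from compound 1 to compound 3 (2.67 log units; beyond the scatter) and an at least 13-fold higher number from compound 2 to compound 3 (1.11 log units; beyond the scatter), can therefore be given only as bounds.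

Compound 4 `COC(=O)c1sc2cc(C#Cc3cccnc3)cnc2c1N` has not yet been measured in this assay. It differs from compound 1 in one place: pyridin-3-yl in place of 4-methoxyphenyl on a triple-bonded carbon. Both measured replacements of the 4-methoxyphenyl by another aromatic ring gave higher numbers, one large, the other running past the limit of this assay. A pyridin-3-yl is a third such replacement, and a higher number than for compound 1 is expected, though with the two measured steps so different in size the extent is uncertain. Compound 4 is therefore estimated to give 4000 nM in this assay, most likely between 800 nM and 30000 nM, which would amount to a 13-fold higher number from compound 1 to compound 4 (1.10 log units; beyond the scatter).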

Compound 4, concentration for 50% growth inhibition: > 150000 nM
Compound 4: no number, only a limit; the forecaster's own chance of this, stated with the estimate: 10%; at least 37-fold (1.57 log units) between middle value and limit.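

Compound 4 shows that a ring with no substituent and one ring nitrogen, pyridin-3-yl, does not keep the growth inhibition seen with the 4-methoxyphenyl in this assay: the result is an at least 460-fold higher number from compound 1 to compound 4 (2.67 log units; beyond the scatter). It also falls short of the 3-aminophenyl, with an at least 13-fold higher number from compound 2 to compound 4 (1.11 log units; beyond the scatter), so among the four groups shown on the triple-bonded carbon, a readable number is kept only by the two substituted rings of compound 1 and compound 2, while compound 3, also substituted, goes against any simple link between a substituent and a readable number. Compound 3 and compound 4 both give a limit and not a number, so the step between them cannot be read and the two cannot be placed in order: the limit of > 150000 nM in this assay, at which 2 of the 4 values shown sit.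

The compounds shown leave open whether the low number of compound 1 depends on the methoxy group itself, which a plain phenyl or an ethoxy group at that place would test. They also leave open whether a pyridin-3-yl carrying a methoxy group would return to a readable number.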